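The source may report more compounds than this note shows. Statements on the series, on what has been measured and on what is new or still open speak of the compounds shown alone.

In a functional assay on C6 cells (Rattus norvegicus) for cytotoxicity, read by MTT assay, with a stated time of 24 h, tested at 6 ug/mL (a higher number here means a weaker effect of the compound at the concentration tested, a lower number a stronger effect), two compounds have been measured:
compound 1, `O=C(CSc1nnnn1-c1ccccc1)N/N=c1/scc(-c2ccc(Br)cc2)n1-c1ccccc1`, gives 61.8%;
compound 2, `Cc1ccc(-c2cs/c(=N/NC(=O)CSc3nnnn3-c3ccccc3)n2-c2ccccc2)cc1`, gives 66.8%.

Compound 2 holds the higher of the two numbers, yet the step from compound 1 to compound 2, a number 5 percentage points higher from compound 1 to compound 2 (within the scatter), is too small to tell the pair apart. Compound 3, `O=C(CSc1nnnn1-c1ccccc1)N/N=c1/scc(-c2ccc(Cl)cc2)n1-c1ccccc1`, differs from compound 2 by chloro in place of methyl on an aromatic carbon. Within the data shown here, only that one exchange at the same aromatic carbon bears on this step, and because it gave a number 5 percentage points higher from compound 1 to compound 2 (within the scatter), a step of only a number 3.8 percentage points lower from compound 2 to compound 3 (within the scatter) is expected. Compound 3 is thus estimated at 63%, between 50% and 76%.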

Compound 3, a percentage reported as activity, at one concentration (the size of the read-out at that concentration, not a potency): 77.4%
For compound 3 the middle estimate is 14.4 percentage points below the measured one; measured number outside the range, above it.
By their numbers in this assay, from the lowest: compounds 1 and 2 (each within the scatter of the next); then compound 3.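

In this assay the group at this ring carbon turns out to matter: the read-out is a number 10.6 percentage points higher from compound 2 to compound 3 (beyond the scatter) and a number 15.6 percentage points higher from compound 1 to compound 3 (beyond the scatter), so compound 3, with chloro, shows the weakest effect of the three. The two halogens also part ways here, as chloro does not match bromo, while compound 1 and compound 2 stay within the scatter of each other. Nothing at hand explains this difference. Going by these compounds, how an amine, a methoxy group or a carboxylic acid at this same carbon would read remains open.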